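The source may hold more compounds than are shown below. What is called first, only, known or untested is meant among the compounds shown, and "the series" means these compounds.

Compound 2 `Cc1cc(C(=O)Nc2cccc(-c3oc4cc(-c5ccc(F)cc5)ccc4c(=O)c3O)c2)ccc1F` is the reference point here. In a functional assay on HepG2 cells (Homo sapiens) for antiproliferative activity, read by CCK-8 assay, with a stated time of 72 h (on this read-out higher numbers stand for weaker inhibition and lower numbers for stronger inhibition), compound 2 gives 9540 nM, and compound 1 `O=C(Nc1cccc(-c2oc3cc(-c4ccc(F)cc4)ccc3c(=O)c2O)c1)c1cccc(F)c1` gives 15500 nM; the two numbers lie within the scatter of each other, as the step of a 1.6-fold lower number from compound 1 to compound 2 (0.21 log units; within the scatter) shows. Compound 3 `COc1ccc(C(=O)Nc2cccc(-c3oc4cc(-c5ccc(F)cc5)ccc4c(=O)c3O)c2)c(F)c1` is not yet measured and differs from compound 2 by 2-fluoro-4-methoxyphenyl in place of 4-fluoro-3-methylphenyl on a carbonyl carbon. Going by the values given here, only that one measured step bears on this change: it also swapped the aryl group on the carbonyl carbon, and it stayed within the scatter. No step beyond the scatter is therefore expected in this assay, and the step of a 1.0-fold lower number from compound 2 to compound 3 (0.00 log units; within the scatter) is the estimate. Compound 3 is expected to give 9500 nM, with a range of 4000 nM to 22000 nM.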

Compound 3, half-maximal inhibitory concentration: 45300 nM
Compound 3: the middle estimate sits 4.8-fold (0.68 log units) below what was measured; measured number above the stated range.
By their numbers in this assay, from the lowest: compounds 2 and 1 (each within the scatter of the next); then compound 3.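

On this assay, the aryl group on the carbonyl carbon does matter: 2-fluoro-4-methoxyphenyl gives a 4.7-fold higher number from compound 2 to compound 3 (0.68 log units; beyond the scatter) in place of 4-fluoro-3-methylphenyl, and a 2.9-fold higher number from compound 1 to compound 3 (0.47 log units; beyond the scatter) in place of 3-fluorophenyl. Both steps mean weaker inhibition, and they show a sensitivity to this group that the earlier swap, which stayed within the scatter, did not reveal. Nothing shown gives a reason for this loss.

On these data alone, the methoxy group and the fluorine's placement change together here, so their separate contributions remain open. Also open, as far as these compounds go, is how a plain 4-methoxyphenyl, or an aryl group bearing an amine or a carboxylic acid, would behave.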